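Adding a Second Fluorine to Compound 1

The source may report more compounds than this note shows. Statements on the series, on what has been measured and on what is new or still open speak of the compounds shown alone.

Compound 1 `Fc1cccc(/C=C/c2ccccc2)c1` is the starting point. Among the measured compounds shown here, in an assay on HepG2 cells for activation of nuclear factor erythroid 2-related factor 2 (Homo sapiens), read by a luciferase reporter, with a stated time of 5 h (on this read-out higher numbers stand for an effect only at larger amounts of compound and lower numbers for an effect already at smaller amounts), compound 1 gives 3100 nM, the highest of the two numbers measured so far. Compound 2 `Fc1cccc(/C=C/c2cccc(F)c2)c1` carries one more fluorine; in this assay compound 2 gives 1000 nM, and the step of a 3.1-fold lower number from compound 1 to compound 2 (0.49 log units; beyond the scatter) is the only one that bears on what follows. Compound 3 `Fc1ccc(/C=C/c2cccc(F)c2)cc1` differs from compound 1 by fluoro in place of hydrogen on an aromatic carbon. A step in the same direction is expected, although its size is uncertain because a 3.1-fold lower number from compound 1 to compound 2 (0.49 log units; beyond the scatter) concerns a different place for the entering fluorine. For compound 3 in this assay the estimate is 1500 nM, between 600 nM and 4000 nM, corresponding to a 2.1-fold lower number from compound 1 to compound 3 (0.32 log units; beyond the scatter).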

Compound 3, half-maximal effective concentration: 650 nM
Compound 3: the middle estimate sits 2.3-fold (0.36 log units) above what was measured; low and high end bracket the measured number.
By their numbers in this assay, from the lowest: compounds 3 and 2 (each within the scatter of the next); then compound 1.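

In this assay the fluoro para to a group of 9 heavy atoms gives a 4.8-fold lower number from compound 1 to compound 3 (0.68 log units; beyond the scatter) on the core of compound 1, so this place also responds to the change. A lower number is not tied to a single place on the ring: compound 2 at 1000 nM and compound 3 at 650 nM stand within the usual scatter of each other.

On these data alone, whether an amine or a carboxylic acid at this same place would also lower the number stays open. No available evidence says why fluoro has this effect.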